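The source may hold more compounds than are shown below. What is called first, only, known or untested is meant among the compounds shown, and "the series" means these compounds.

Compound 3 `C1=C(c2cccnc2)C[C@@H]2CNC[C@H]1C2` gives 35 nM in an in vitro functional assay on SH-EP1 cells for agonist activity at Neuronal acetylcholine receptor; alpha4/beta2 (Homo sapiens), read by FLIPR and calcium flux; on this read-out lower numbers stand for an effect already at smaller amounts and higher numbers for an effect only at larger amounts of compound. Among the three compounds measured so far it stands second highest. Compound 2 `C1=C(c2cccnc2)C[C@H]2CNC[C@@H]1C2` gives 12 nM, the lowest number of the set, and compound 1 `CN1C[C@H]2C=C(c3cccnc3)C[C@H](C2)C1` gives 7660 nM, the highest. Two measured steps connect these compounds. Because of the fact that compounds 2 and 3 differ only in the configuration as drawn, the step of a 2.9-fold higher number from compound 2 to compound 3 (0.46 log units; beyond the scatter) reflects configuration alone and is modest. Removing the methyl from the amine nitrogen in the ring produced a 640-fold lower number from compound 1 to compound 2 (2.81 log units; beyond the scatter), a large drop in the number.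

Compound 4 `CN1C[C@@H]2C=C(c3cccnc3)C[C@@H](C2)C1` has not yet been measured. Set beside compound 3, the change is methyl in place of hydrogen on an amine nitrogen in a ring. This is the same methyl, on the same nitrogen, that separates compound 1 from compound 2, only now put on rather than taken off. Because the opposite move gave a 640-fold lower number from compound 1 to compound 2 (2.81 log units; beyond the scatter), the number for compound 4 is expected to rise sharply, and the step is estimated as a 570-fold higher number from compound 3 to compound 4 (2.76 log units; beyond the scatter). The comparison with compound 1, whose mirror image compound 4 is, points the same way. Compound 4 is therefore expected to give about 20000 nM, with a likely range from 5000 nM to 80000 nM.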

Compound 4, half-maximal effective concentration: > 10000 nM
Compound 4: no number, only a limit; the forecaster's own chance of this, stated with the estimate: 25%; the middle value lies beyond the limit too.
By their numbers in this assay, from the lowest: compound 2; then compound 3; then compound 1. At a limit, above all of these: compound 4.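

Compound 4 gives > 10000 nM in this assay, and that value is a limit of the assay, not a number. Even so, the methyl on the amine nitrogen in a ring now gives a large step on the mirror-image core as well, an at least 280-fold higher number from compound 3 to compound 4 (2.45 log units; beyond the scatter), so the large effect of this change is no longer tied to a single configuration: the same change on two cores in this assay, a 640-fold lower number (2.81 log units; beyond the scatter) from compound 1 to compound 2 and an at least 280-fold lower number (2.45 log units; beyond the scatter) from compound 4 to compound 3; the limit leaves it open whether they differ. Without the methyl, the mirror images are separated by a 2.9-fold higher number from compound 2 to compound 3 (0.46 log units; beyond the scatter), whereas with the methyl the step is an at least 1.3-fold higher number from compound 1 to compound 4 (0.11 log units; that floor lies within the scatter), a floor that cannot show whether configuration still matters once the methyl is present: the fact that compounds 1 and 4 differ only in the configuration as drawn.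

On these data alone, the true value of compound 4 stays unknown, and with it whether the methyl step is the same size on both mirror-image cores and how far the two methylated mirror images lie apart. Only hydrogen and methyl appear on this nitrogen, so the compounds shown leave open what an ethyl group, a longer chain or an acetyl group there would do to the number.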